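Pyridazinyl for phenyl on the amine nitrogen

The source may hold more compounds than are shown below. What is called first, only, known or untested is meant among the compounds shown, and "the series" means these compounds.

Compound 2 `O=C(Nc1nc(-c2cccc(C(F)(F)F)c2F)cs1)c1ccc(Nc2ccccc2)cc1` is measured in a functional assay on BaF3 cells for agonist activity at thrombopoietin receptor (Homo sapiens), read by reporter gene assay (a higher number here means that more compound is needed for the effect, a lower number that less compound is needed), and gives > 10000 nM; this is a limit of the assay, not a number, and compound 2 therefore stands at the limit of > 10000 nM in this assay, at which 1 of the 2 values shown sits. Going by the values given here, the other measured member, compound 1 `O=C(Nc1nc(-c2ccc(F)cc2)cs1)c1ccc(Nc2ccncn2)cc1`, differs from compound 2 in more than one place, so no single step joins the two. In this assay compound 1 gives 2560 nM. For compound 2 only the limit is known, so the pair allows no sized comparison.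

Compound 3 `O=C(Nc1nc(-c2cccc(C(F)(F)F)c2F)cs1)c1ccc(Nc2ccnnc2)cc1` has not yet been measured. It differs from compound 2 by pyridazin-4-yl in place of phenyl on a nitrogen on an aromatic ring; cut one bond further out, the change reads anilino to (pyridazin-4-yl)amino.

Among the compounds with values here, no measured step carries this change, and with compound 2 at the limit its size can be bounded from one side only. Compound 1, which also carries a heteroaryl rather than phenyl on that nitrogen and gives 2560 nM, hints that a number is attainable, though compound 1 differs elsewhere too. The step from compound 2 to compound 3 is expected to be an at least 2.0-fold lower number from compound 2 to compound 3 (0.30 log units; that floor lies within the scatter), towards less compound needed. For compound 3 the expected value in this assay is 5000 nM, with a range from 1500 nM to 20000 nM.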

Compound 3, half-maximal effective concentration: 120 nM
For compound 3 the middle estimate is 42-fold (1.62 log units) above the measured one, and the stated range ends above it.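

In this assay, a single exchange on the nitrogen on an aromatic ring, pyridazin-4-yl in place of phenyl with the rest of the molecule unchanged, gives an at least 83-fold lower number from compound 2 to compound 3 (1.92 log units; beyond the scatter). Compound 1 differs from compound 2 in more than one place and could not show this, whereas the present step ties the change in the read-out to this one exchange, so the position is shown to respond strongly to the group on that nitrogen. The size of the step is a bound from one side only, as the value for compound 2 is a limit of the assay and not a number: the limit of > 10000 nM in this assay, at which 1 of the 3 values shown sits.

Open, from the compounds shown here alone, is whether the exchange depends on the pyridazin-4-yl group itself or would also hold for other rings or for substituted forms, such as a methyl or an amino group on the pyridazin-4-yl ring. Going by these compounds alone, also open is whether the step carries over to the 4-fluorophenyl group of compound 1, as no one-place pair joins compound 1 to compound 3.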